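Adding a chloro group to the phenyl of compound 1

The compounds below may be only part of what the source reports. "The series", "measured", "known", "first", "only" and "open" are said of these compounds alone.

Measured compounds:
- Compound 1, `COc1cc(/C=C/C(=O)c2cccc(-n3cc(-c4ccccc4)[nH]c3=O)c2)ccc1O`: 1680 nM
- Compound 2, `COc1ccc(-c2cn(-c3cccc(C(=O)/C=C/c4cc(OC)c(OC)c(OC)c4)c3)c(=O)[nH]2)cc1`: 4210 nM
- Compound 3, `COc1cc(/C=C/C(=O)c2cccc(-n3cc(-c4cc(OC)c(OC)c(OC)c4)[nH]c3=O)c2)cc(OC)c1OC`: 20300 nM

In a functional assay on A498 cells (Homo sapiens) for inhibition (a higher number here means a weaker inhibitor of growth, a lower number a stronger inhibitor of growth), compound 1 gives the lowest number of the three, with compound 2 next and compound 3 furthest away; these gaps lie beyond the scatter. Compound 4, `COc1cc(/C=C/C(=O)c2cccc(-n3cc(-c4ccc(Cl)cc4)[nH]c3=O)c2)ccc1O`, is the unmeasured partner: chloro in place of hydrogen on an aromatic carbon, placed on an aromatic carbon of a six-membered aromatic ring of carbon only, para to a large group. For the measured compounds named here, only one measured step touches this part of the core, the step of a 4.8-fold higher number from compound 2 to compound 3 (0.68 log units; beyond the scatter), where additional methoxy groups made the inhibitor weaker. That step does not involve a chloro group, so it bears only loosely on the present change; a single chloro group is a much smaller addition than two extra methoxy groups. The expectation is therefore a step of a 1.1-fold higher number from compound 1 to compound 4 (0.05 log units; within the scatter) that stays within the scatter, with a slight lean toward a higher number. Compound 4 is estimated at 1900 nM, within a range from 700 nM to 5500 nM.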

Compound 4, concentration for 50% growth inhibition: 2820 nM
The estimate for compound 4 lay 1.5-fold (0.17 log units) below the measured number, within the range that was stated.
By their numbers in this assay, from the lowest: compounds 1, 4 and 2 (each within the scatter of the next, the first and the last beyond it); then compound 3.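

In this assay, chloro in place of hydrogen on the phenyl of compound 1, para to a large group, gives a step (a 1.7-fold higher number from compound 1 to compound 4 (0.22 log units; within the scatter)) that leaves the two compounds indistinguishable. This is the only step shown that adds a single heavy atom, and it shows that this phenyl can carry a chlorine without a shift beyond the scatter, whereas the added methoxy groups gave a step beyond it (a 4.8-fold higher number from compound 2 to compound 3 (0.68 log units; beyond the scatter)). Nothing shown gives a reason for this result.

From the compounds shown here alone, whether an amine or a carboxylic acid at this same place would also stay within the scatter remains open. So does whether chloro in place of hydrogen would give a similar step on a core other than that of compound 1.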